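The source may report more compounds than this note shows. Statements on the series, on what has been measured and on what is new or still open speak of the compounds shown alone.

Compound 1 `NS(=O)(=O)Oc1ccc2c(c1)CN(C(=O)c1cccc(N(Cc3ccccc3)Cc3ccco3)c1)CC2` carries a benzyl and a furanylmethyl on the ring nitrogen; in an assay on HEK293 cells for inhibition of Steryl-sulfatase (Homo sapiens), tested at 1 uM (on this read-out higher numbers stand for a stronger effect at the one concentration tested and lower numbers for a weaker effect), compound 1 gives 90.5%, the highest of the three numbers shown. Compound 2 `CCCN(CCC)c1ccc(C(=O)N2CCc3ccc(OS(N)(=O)=O)cc3C2)cc1` gives 84.7% in this assay, which lies within the usual scatter of compound 1. Compound 3 `NS(=O)(=O)Oc1ccc2c(c1)CN(C(=O)c1cccc(N3CCCCC3)c1)CC2`, with a piperidine in place of the open-chain nitrogen, gives 11.9% in this assay, far below the other two. Compound 4 `CN(C)CCN(Cc1ccccc1)c1cccc(C(=O)N2CCc3ccc(OS(N)(=O)=O)cc3C2)c1` is not yet measured; it differs from compound 1 by (dimethylamino)methyl in place of furan-2-yl on a saturated chain carbon bound to a nitrogen on an aromatic ring. Open-chain substituents on this nitrogen are tolerated in compound 1 and compound 2, so the step of a number 12.5 percentage points lower from compound 1 to compound 4 (beyond the scatter) is expected to be small, or none beyond the scatter, in this assay. Compound 4 is estimated at 78%, within 50% to 95%.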

Compound 4, a percentage reported as inhibition, at one concentration (the size of the read-out at that concentration, not a potency): 28.6%
For compound 4 the middle estimate is 49.4 percentage points above the measured one; the measured number lies below the stated range.
By their numbers in this assay, from the lowest: compound 3; then compound 4; then compounds 2 and 1 (each within the scatter of the next).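

In this assay, replacing furan-2-yl with (dimethylamino)methyl on a saturated chain carbon bound to a nitrogen on an aromatic ring gives a large step of a number 61.9 percentage points lower from compound 1 to compound 4 (beyond the scatter) even though the benzyl stays in place. This place is therefore sensitive to what it carries, and an open-chain nitrogen alone does not settle the outcome. Nothing measured here explains the drop.

This single step swaps an aromatic ring for an amine-bearing chain, so the two parts cannot be separated. A thiophene, a phenyl or a methoxyethyl chain at this place could tell them apart.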